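The compounds below may be only part of what the source reports. "The series", "measured", "known", "first", "only" and "open" are said of these compounds alone.

In a functional assay on HONE1 cells for cytotoxicity against HONE1 cell line (Homo sapiens) (a lower number here means a stronger inhibitor, a higher number a weaker inhibitor), three close analogues have been measured. Compound 1 `N#C/N=C1\N(CCCCCOc2ccc(Cl)cc2)C(=O)CN1c1ccncc1` gives 3400 nM, compound 2 `N#C/N=C1\N(CCCCCCOc2ccc(Cl)cc2)C(=O)CN1c1ccncc1` gives 2960 nM, and compound 3 `CC1C(=O)N(CCCCCOc2ccc(Cl)cc2)/C(=N\C#N)N1c1ccncc1` gives 3680 nM. Compound 3 stands alongside the other two, its number separated from those of compound 1 and compound 2 by less than the usual scatter, so no order among the three can be read. Compound 4 `CC1C(=O)N(CCCCCCOc2ccc(Cl)cc2)/C(=N\C#N)N1c1ccncc1` differs from compound 3 by (4-chlorophenoxy)methyl in place of 4-chlorophenoxy on a saturated chain carbon, five bonds along the chain from an amide-type nitrogen in a ring. The same chain extension has already been seen once: a 1.1-fold lower number from compound 1 to compound 2 (0.06 log units; within the scatter), a step within the scatter. The methyl that compound 3 and compound 4 share likewise left the number essentially unchanged, as a 1.1-fold higher number from compound 1 to compound 3 (0.03 log units; within the scatter) shows. Compound 4 is therefore expected to show no step beyond the scatter, a 1.1-fold lower number from compound 3 to compound 4 (0.05 log units; within the scatter), and its estimated value in this assay is 3300 nM, within a range of 1700 nM to 6500 nM.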

Compound 4, half-maximal inhibitory concentration: 303 nM
Compound 4: middle estimate off by 11-fold (1.04 log units), on the high side; measured number below the stated range.
By their numbers in this assay, from the lowest: compound 4; then compounds 2, 1 and 3 (each within the scatter of the next).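

In this assay, the change to (4-chlorophenoxy)methyl on this saturated chain carbon gives a 12-fold lower number from compound 3 to compound 4 (1.08 log units; beyond the scatter) when the methyl is on the saturated ring carbon, and that methyl gives a 9.8-fold lower number from compound 2 to compound 4 (0.99 log units; beyond the scatter) when the chain carries (4-chlorophenoxy)methyl. The step from the chain change therefore depends on the core that carries it: the same change on two cores in this assay, a 1.1-fold lower number (0.06 log units; within the scatter) from compound 1 to compound 2 and a 12-fold lower number (1.08 log units; beyond the scatter) from compound 3 to compound 4, 11-fold (1.02 log units) apart, beyond the scatter of two such steps. The methyl step depends in the same way on the chain: the same change on two cores in this assay, a 1.1-fold higher number (0.03 log units; within the scatter) from compound 1 to compound 3 and a 9.8-fold lower number (0.99 log units; beyond the scatter) from compound 2 to compound 4, 11-fold (1.02 log units) apart, beyond the scatter of two such steps. The compounds shown leave open whether a longer chain or an ethyl on the same ring carbon would keep this lower number, since the pairing rests on compound 4 alone.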